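Swapping the pyrazole on the aminopyrimidine anchor

A few compounds are considered here, and "the series" means these few. Any claim that something is new, unique, unknown or untested is made for them only; others in the source may bear on it.

Compound 1: `C[C@@H]1CCCN1c1c(C#N)c2c(N)nc(Nc3cn[nH]c3)nc2n1C`, 6 nM
Compound 2: `Cc1cn(C)nc1Nc1cc2c(c(N)n1)c(C#N)c(N1CCC[C@H]1C)n2C`, 2110 nM
Compound 3: `Cc1nn(CC(C)(C)O)cc1Nc1nc(N)c2c(C#N)c(N3CCC[C@H]3C)n(C)c2n1`, 49 nM

In an assay on isolated protein for inhibition of Leucine-rich repeat serine/threonine-protein kinase 2 (Homo sapiens), read by TR-FRET and LanthaScreen, with stated times of 50 min and 30 min, in the presence of a further agent that is not named here (a lower number here means a stronger inhibitor, a higher number a weaker inhibitor), compound 1 gives the lowest number of the three; compound 3, which carries a methyl and a hydroxy-dimethylethyl on its pyrazole, gives a higher number, and compound 2, built on a different core with a differently attached pyrazole, gives a much higher one. Compound 4 is `C[C@@H]1CCCN1c1c(C#N)c2c(N)nc(Nc3cn(C)nc3Cl)nc2n1C`. It differs from compound 1 only in the change (3-chloro-1-methyl-1H-pyrazol-4-yl in place of 1H-pyrazol-4-yl on a nitrogen on an aromatic ring), so the donor on the ring nitrogen is lost and a chlorine is gained. Compound 3 shows that decorating this pyrazole costs potency, so a moderate rise in number is expected: a 5.0-fold higher number from compound 1 to compound 4 (0.70 log units; beyond the scatter). Compound 4 is therefore estimated at 30 nM, in the range 8 nM to 120 nM.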

Compound 4, half-maximal inhibitory concentration: 34 nM
For compound 4 the middle estimate is 1.1-fold (0.05 log units) below the measured one, and the stated range covers the measured number.
By their numbers in this assay, from the lowest: compound 1; then compounds 4 and 3 (each within the scatter of the next); then compound 2.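

Going by these compounds alone, replacing 1H-pyrazol-4-yl with 3-chloro-1-methyl-1H-pyrazol-4-yl on the shared core gives a 5.7-fold higher number from compound 1 to compound 4 (0.75 log units; beyond the scatter) as the first reading of this position with nothing else changed. The hydrogen-bond donor is lost and a methyl and a chlorine are gained, yet the step is only modest, so this position accepts the larger group. No available measurement explains the rise.

The methyl and chlorine enter together, so their separate contributions cannot be told apart. From the compounds shown here alone, how an amine or a longer chain here would read remains open.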